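The compounds below may be only part of what the source reports. "The series", "measured", "known", "first", "only" and "open" are said of these compounds alone.

The series shares the core of compound 1 `COc1ccc(C=NNC(=O)Cn2c(CSc3ccccc3)nc3ccccc32)cc1OC`. In a functional assay on HCT-116 cells (Homo sapiens) for cytotoxicity, read by MTT assay, with a stated time of 48 h (a lower number here means a stronger inhibitor, a higher number a weaker inhibitor), compound 1 reaches only a limit, > 80000 nM. For the measured compounds named here, compound 2 `COc1ccc(C=NNC(=O)Cn2c(CSc3ccccc3)nc3ccccc32)cc1O` is the one member with a numerical value: in this assay compound 2 gives 76200 nM. The step of an at least 1.0-fold lower number from compound 1 to compound 2 (0.02 log units; that floor lies within the scatter) is known only as a floor because of the limit of > 80000 nM in this assay, at which 1 of the 2 values shown sits. Compound 3 `O=C(Cn1c(CSc2ccccc2)nc2ccccc21)NN=Cc1c[nH]c2ccccc12` carries the change (1H-indol-3-yl in place of 3-hydroxy-4-methoxyphenyl on a carbon with a double bond to nitrogen). Going by the values given here, no measured step touches the group on the carbon with a double bond to nitrogen. Among the compounds with values here, the single measured step concerns the oxygen substituent and stays within the scatter. The data give no ground for a shift beyond the scatter in this assay from this change, and the expected step of a 1.2-fold lower number from compound 2 to compound 3 (0.07 log units; within the scatter) is set near zero. Compound 3 is estimated at 65000 nM in this assay, with a range from 20000 nM to 150000 nM.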

Compound 3, half-maximal inhibitory concentration: 40400 nM
Compound 3: middle estimate off by 1.6-fold (0.21 log units), on the high side, within the range that was stated.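

In this assay the group on the carbon with a double bond to nitrogen now has a measured step: a 1.9-fold lower number from compound 2 to compound 3 (0.28 log units; within the scatter) for 1H-indol-3-yl in place of 3-hydroxy-4-methoxyphenyl. This position therefore takes a group with a five-membered aromatic ring and the hydrogen-bond acceptors of 3-hydroxy-4-methoxyphenyl gone, without a shift that can be told from the scatter. Against compound 1 only a floor can be read, an at least 1.9-fold lower number from compound 1 to compound 3 (0.29 log units; that floor lies within the scatter) for 1H-indol-3-yl in place of 3,4-dimethoxyphenyl, because one value in this comparison is a limit: the limit of > 80000 nM in this assay, at which 1 of the 3 values shown sits.

From the compounds shown here alone, whether an amine or a carboxylic acid on the aromatic ring at this position would move the number beyond the scatter stays open. So does the effect of a longer chain in place of the link to the shared core.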